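The source may hold more compounds than are shown below. What is called first, only, known or untested is meant among the compounds shown, and "the series" means these compounds.

Values so far in a physicochemical assay for solubility, read by nephelometry, measured as kinetic solubility; on this read-out lower numbers stand for lower solubility and higher numbers for higher solubility

- compound 1 `CC[C@H]1CC[C@@H](n2c(=O)[nH]c3ncc(NC(C)=O)cc3c2=O)CC1` gives 48000 nM
- compound 2 `CC(C)[C@H]1CC[C@@H](n2c(=O)[nH]c3ncc(N)cc3c2=O)CC1` gives 17000 nM
- compound 3 `CC[C@H]1CC[C@H](n2c(=O)[nH]c3ncc(N)cc3c2=O)CC1` gives 55000 nM

In this assay compound 3 (55000 nM) lies within the scatter of compound 1 and beyond the scatter above compound 2. Compound 4 `CC[C@H]1CC[C@@H](n2c(=O)[nH]c3ncc(N)cc3c2=O)CC1` is still unmeasured. The change is the two compounds have the same atoms and bonds and differ only in configuration as drawn: 2 of 2 stereo elements differ (all stereocentres are inverted: mirror images); a stereocentre at a saturated ring carbon is drawn r in compound 3 and s in compound 4; a stereocentre at a saturated ring carbon is drawn r in compound 3 and s in compound 4 (same atoms and bonds, all stereocentres inverted, both at saturated ring carbons). No measured pair sizes such a change, so no step beyond the scatter is expected, in either direction. That expectation rests only on compound 3 (55000 nM) as the starting value. The estimated change is a 1.4-fold lower number from compound 3 to compound 4 (0.14 log units; within the scatter) (slightly downward, if at all). For compound 4 the expected value is 40000 nM (estimated range 17000 nM to 90000 nM).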

Compound 4, solubility: < 17000 nM
Compound 4: only a limit was reported; the forecaster's own chance of this, stated with the estimate: 10%; at least 2.3-fold (0.37 log units) between middle value and limit.
By their numbers in this assay, from the lowest: compound 2; then compounds 1 and 3 (each within the scatter of the next).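

In this assay, inverting both stereocentres at saturated ring carbons, with atoms and bonds unchanged, now has a size: an at least 3.2-fold lower number from compound 3 to compound 4 (0.50 log units; beyond the scatter). Hydrogen in place of acetyl on a nitrogen on an aromatic ring also gives a step, an at least 2.8-fold lower number from compound 1 to compound 4 (0.45 log units; beyond the scatter), while hydrogen in place of methyl on a saturated chain carbon bound to a saturated chain carbon and a saturated ring carbon gives a number no higher from compound 2 to compound 4 (the limit leaves the size open) as a step whose size cannot be read. Compound 4 carries only a limit of the assay, not a number: the limit of < 17000 nM in this assay, at which 1 of the 4 values shown sits.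

On these data alone, the actual value of compound 4 remains open. Also open, as far as these compounds go, is whether inverting these stereocentres gives a similar step with a longer chain in place of ethyl.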